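Swapping Fluoro for Chloro on a Benzyl Ring

This account rests on a few compounds, and the source may have more. Where it says the series, first, only, none or still open, it means among the compounds named here.

Compound 1 `Cc1ccc(Cn2c(CN3CCN(C(=O)C4CC4)CC3)nc3ccccc32)cc1`: 51.5%
Compound 2 `O=C(C1CC1)N1CCN(Cc2nc3ccccc3n2Cc2ccc(F)cc2)CC1`: 32.7%

For the measured compounds named here, in an assay on isolated protein for inhibition of aldehyde dehydrogenase 1A1 (Homo sapiens), read by spectrophotometry, tested at 10 uM (on this read-out higher numbers stand for more inhibition at the one concentration tested (going by the name of the read-out) and lower numbers for less inhibition), compound 2 gives 32.7%, the lower of the two numbers measured so far. Compound 1 gives 51.5% in this assay. Compound 3 `O=C(C1CC1)N1CCN(Cc2nc3ccccc3n2Cc2ccc(Cl)cc2)CC1` differs from compound 2 by chloro in place of fluoro on an aromatic carbon. Going by the values given here, one measured step bears on this position: a number 18.8 percentage points lower from compound 1 to compound 2 (beyond the scatter), a modest loss when methyl became fluoro. Among the compounds with values here, no step shows chloro directly, so the expectation rests on that single comparison. A modest rise back toward compound 1 is therefore expected: a number 9.3 percentage points higher from compound 2 to compound 3 (within the scatter). Compound 3 is estimated at 42%, with a range from 25% to 60%.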

Compound 3, a percentage reported as inhibition, at one concentration (the size of the read-out at that concentration, not a potency): 56.6%
The estimate for compound 3 lay 14.6 percentage points below the measured number; the range from low to high includes it.
By their numbers in this assay, from the lowest: compound 2; then compounds 1 and 3 (each within the scatter of the next).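

Fluoro and chloro do not behave alike at this position on the benzyl ring: in this assay, chloro in place of fluoro gives a number 23.9 percentage points higher from compound 2 to compound 3 (beyond the scatter) and so recovers what the earlier swap of methyl for fluoro had lost. Chloro in place of methyl gives a number 5.1 percentage points higher from compound 1 to compound 3 (within the scatter), so these two groups cannot be told apart on this read-out. Nothing measured here explains why fluoro stands apart from them. Still open, going by these compounds, is how bromo, methoxy or trifluoromethyl would fare at this place on the ring.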